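Working notes on tolerated concentration across four compounds

This account rests on a few compounds, and the source may have more. Where it says the series, first, only, none or still open, it means among the compounds named here.

Measured so far in an ADME assay on Vero cells (Chlorocebus sabaeus) for cytotoxicity, read by MTT assay, with a stated time of 96 h; a higher number here means that more compound is tolerated, a lower number that less compound is tolerated:
compound 1 `C/C(=N\NC(N)=S)c1ccc2[nH]c(-c3ccccc3)nc2c1` gives > 100000 nM.
compound 2 `COc1ccc(-c2nc3cc(/C(C)=N/NC(N)=S)ccc3[nH]2)cc1` gives > 100000 nM.
compound 3 `COc1ccc(-c2nc3cc(C(C)=O)ccc3n2C2CCCCC2)cc1` gives 30000 nM.

The value for compound 1 is a limit of this assay, not a number. The value for compound 2 is likewise a limit. The step that the two limits leave unreadable from compound 1 to compound 2 therefore stays unreadable, as shown by the limit of > 100000 nM in this assay, at which 2 of the 3 values shown sit; the change made is methoxy in place of hydrogen on an aromatic carbon. Going by the values given here, compound 3 carries the only number in this assay. Compound 3 and compound 1 differ in more than one place, and the difference between the two cores is not broken down here.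

Compound 4 `COc1ccc(-c2nc3cc(C(C)=O)ccc3n2C2CCCCC2)c(OC)c1` is not yet measured. It differs from compound 3 by methoxy in place of hydrogen on an aromatic carbon. This is the same kind of change as from compound 1 to compound 2, but the place differs: in compound 2 the methoxy sits para to a large group, in compound 4 ortho to a large group and meta to a methoxy group. With the earlier step unreadable, the expectation for compound 4 rests on compound 3 at 30000 nM and on the added methoxy being a small group. The expected step is a 1.2-fold higher number from compound 3 to compound 4 (0.07 log units; within the scatter), within the usual scatter. Compound 4 is estimated at 35000 nM, from 12000 nM to 100000 nM.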

Compound 4, half-maximal cytotoxic concentration: 70000 nM
Compound 4: the middle estimate sits 2.0-fold (0.30 log units) below what was measured, and the stated range covers the measured number.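

In this assay, methoxy in place of hydrogen on an aromatic carbon gives a 2.3-fold higher number from compound 3 to compound 4 (0.37 log units; beyond the scatter), a modest step beyond the scatter, on the core of compound 3, with the entering methoxy ortho to a large group and meta to a methoxy group. The same kind of change from compound 1 to compound 2 cannot be read, because the values on both sides are limits of the assay and not numbers: the limit of > 100000 nM in this assay, at which 2 of the 4 values shown sit. The series therefore offers one readable step on one core at one place, which shows that the change can raise the tolerated concentration there but does not show whether it carries over to the core of compound 1, where the methoxy also stands in a different place.

Still open, as far as these compounds go, is whether the step belongs to methoxy itself or would also appear with ethoxy, a longer chain, or with an amine at the same place. Also open, from the compounds shown here alone, is whether a carboxylic acid there would move the number in the opposite direction.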